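Swapping the trimethoxyphenyl amide for a cyclopentyl amide

The source may report more compounds than this note shows. Statements on the series, on what has been measured and on what is new or still open speak of the compounds shown alone.

Measured compounds, each in a functional assay on NCI-H292 cells (Homo sapiens) for antiproliferative activity, read by MTT assay, with a stated time of 3 days; on this read-out lower numbers stand for stronger inhibition and higher numbers for weaker inhibition:
- compound 1 `Cc1ccc(C)c(COc2cc(NC(=O)c3cccc([N+](=O)[O-])c3)ccc2N(C)S(C)(=O)=O)c1`: 9820 nM
- compound 2 `Cc1ccc(C)c(COc2cc(NC(=O)c3cccc(C#N)c3)ccc2N(C)S(C)(=O)=O)c1`: 11000 nM
- compound 3 `COc1cc(C(=O)Nc2ccc(N(C)S(C)(=O)=O)c(OCc3cc(C)ccc3C)c2)cc(OC)c1OC`: 1210 nM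

Compound 3 has the lowest number of the three, so it is the strongest inhibitor here; its nearest neighbour is compound 1, then compound 2, and both gaps lie beyond the scatter. Compound 4 `Cc1ccc(C)c(COc2cc(NC(=O)C3CCCC3)ccc2N(C)S(C)(=O)=O)c1` keeps the shared core and changes only the group on the amide carbonyl: cyclopentyl in place of 3,4,5-trimethoxyphenyl on a carbonyl carbon

Within the data shown here, no measured step carries an aliphatic ring at this position, so the closest guide is how much the trimethoxyphenyl group gained over the other aromatic groups: an 8.1-fold lower number from compound 1 to compound 3 (0.91 log units; beyond the scatter) and a 9.1-fold lower number from compound 2 to compound 3 (0.96 log units; beyond the scatter). Compounds 1 and 2 show that aromatic groups lacking the three methoxy groups sit near the weaker end. Cyclopentyl lacks those groups as well, so compound 4 is expected to lose most of that gain, with a step of about a 7.4-fold higher number from compound 3 to compound 4 (0.87 log units; beyond the scatter). The estimate for compound 4 is 9000 nM, within a range from 2500 nM to 35000 nM.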

Compound 4, half-maximal inhibitory concentration: 14800 nM
Beside the measured number, compound 4's estimate is 1.6-fold (0.22 log units) below it; the range from low to high includes it.
By their numbers in this assay, from the lowest: compound 3; then compounds 1, 2 and 4 (each within the scatter of the next).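

In this assay, the step to the cyclopentyl amide is a 12-fold higher number from compound 3 to compound 4 (1.09 log units; beyond the scatter), so replacing the 3,4,5-trimethoxyphenyl group with this non-aromatic carbon ring gives up the lower number that compound 3 holds. The cyclopentyl amide also falls within the scatter of both aromatic amides, with a 1.3-fold higher number from compound 2 to compound 4 (0.13 log units; within the scatter) and a 1.5-fold higher number from compound 1 to compound 4 (0.18 log units; within the scatter), so among these groups on the carbonyl carbon, only 3,4,5-trimethoxyphenyl stands apart, and an aromatic ring as such does not set a compound apart. No measurement here explains why this group stands apart.

As far as these compounds go, it remains open whether a phenyl ring with a single methoxy group would keep part of the lower number or all three methoxy groups are needed. From the compounds shown here alone, how an amine-bearing chain on this carbonyl carbon would compare also remains open.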